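Methoxy in Place of Methyl on the Sulfonamide Aryl Ring

The source may report more compounds than this note shows. Statements on the series, on what has been measured and on what is new or still open speak of the compounds shown alone.

Measured compounds:
compound 1, `Cc1cccc(NS(=O)(=O)c2ccc(N3CCNC3=O)cc2)c1`: 110 nM
compound 2, `CCc1ccc(NS(=O)(=O)c2ccc(N3CCNC3=O)cc2)cc1`: 660 nM
compound 3, `O=C1NCCN1c1ccc(S(=O)(=O)Nc2cccc(Cl)c2)cc1`: 55 nM

In a functional assay on HT-29 cells (Homo sapiens) for antiproliferative activity, read by sulforhodamine B assay, with a stated time of 48 h (on this read-out higher numbers stand for weaker inhibition and lower numbers for stronger inhibition), compound 1 gives 110 nM, the second highest of the three numbers. The nearest neighbour is a step of a 2.0-fold lower number from compound 1 to compound 3 (0.30 log units; within the scatter) away, which stays within the scatter; the furthest is a step of a 6.0-fold higher number from compound 1 to compound 2 (0.78 log units; beyond the scatter), beyond the scatter. Compound 4, `COc1cccc(NS(=O)(=O)c2ccc(N3CCNC3=O)cc2)c1`, differs from compound 1 in one place: methoxy in place of methyl on an aromatic carbon. Among the measured compounds shown here, the only measured step that bears on it is the exchange at the same place, a 2.0-fold lower number from compound 1 to compound 3 (0.30 log units; within the scatter), which changed little. For the measured compounds named here, no measured pair swaps methyl for methoxy. A step within the scatter is therefore expected, with no clear direction. Compound 4 is expected to give 150 nM, between 50 nM and 450 nM, a step of a 1.4-fold higher number from compound 1 to compound 4 (0.13 log units; within the scatter) that is expected to stay within the scatter.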

Compound 4, half-maximal inhibitory concentration: 120 nM
Compound 4: middle estimate off by 1.3-fold (0.10 log units), on the high side; measured number inside the range.
By their numbers in this assay, from the lowest: compounds 3, 1 and 4 (each within the scatter of the next, the first and the last beyond it); then compound 2.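

At this place on the ring, methoxy and methyl cannot be told apart (a 1.1-fold higher number from compound 1 to compound 4 (0.04 log units; within the scatter)), so the added oxygen and hydrogen-bond acceptor bring no shift beyond the scatter. Methoxy does separate from chloro (a 2.2-fold higher number from compound 3 to compound 4 (0.34 log units; beyond the scatter)), a modest step that the exchange of methyl for chloro did not produce. The 3-methoxyphenyl group, like the 3-methylphenyl group, stands apart from the 4-ethylphenyl group (a 5.5-fold lower number from compound 2 to compound 4 (0.74 log units; beyond the scatter)).

No measurement at hand explains these differences. On these data alone, whether an amine or a carboxylic acid at this place would stay close to compound 4 remains open.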